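The source may report more compounds than this note shows. Statements on the series, on what has been measured and on what is new or still open speak of the compounds shown alone.

Measured in a functional assay on 786-0 cells (Homo sapiens) for inhibition, with a stated time of 48 h; on this read-out higher numbers stand for weaker inhibition of growth and lower numbers for stronger inhibition of growth:
- compound 1 `COc1ccccc1/C=C/C(=O)c1c(O)cc2occc2c1OC`: 35300 nM
- compound 2 `COc1c(C(=O)/C=C/c2ccc(Cl)cc2)c(O)c(Br)c2occc12`: 2990 nM
- compound 3 `C=CCc1c(O)c(C(=O)/C=C/c2ccccc2)c(OC)c2ccoc12`: 4120 nM

Compound 3 lies within the scatter of compound 2 and well under compound 1, which has the highest number of the three. The next step leads to compound 4 `C=CCc1c(O)c(C(=O)/C=C/c2ccc(Cl)cc2)c(OC)c2ccoc12`: chloro in place of hydrogen on an aromatic carbon, or phenyl to 4-chlorophenyl. For the measured compounds named here, this change has no measured pair. Compound 2 carries the 4-chlorophenyl group but differs elsewhere, and compound 2 gives 2990 nM. In this assay, no step beyond the scatter is expected, with any drift toward a lower number. The expected step is a 1.3-fold lower number from compound 3 to compound 4 (0.11 log units; within the scatter). Compound 4 is estimated at 3200 nM, with an expected range of 1400 nM to 7000 nM.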

Compound 4, concentration for 50% growth inhibition: 4830 nM
For compound 4 the middle estimate is 1.5-fold (0.18 log units) below the measured one; the range from low to high includes it.
By their numbers in this assay, from the lowest: compounds 2, 3 and 4 (each within the scatter of the next); then compound 1.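

In this assay, chloro in place of hydrogen on an aromatic carbon, para to a large group, gives a 1.2-fold higher number from compound 3 to compound 4 (0.07 log units; within the scatter), so this position accepts chloro with no step beyond the scatter. Allyl in place of bromo on an aromatic carbon gives a 1.6-fold higher number from compound 2 to compound 4 (0.21 log units; within the scatter), the first reading of that second position, and it also stays within the scatter. No evidence on cause bears on these results.

As far as these compounds go, what an amine or a carboxylic acid in place of chloro would do in this assay stays open, as does the effect of a longer chain in place of allyl.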